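The source may hold more compounds than are shown below. What is called first, only, known or untested is meant among the compounds shown, and "the series" means these compounds.

Working notes on the series. Compound 1 `COc1ccc(-c2cnc(NC(=O)c3cccc(C#N)c3)n2C)cc1` and compound 2 `COc1ccc(-c2cnc(NC(=O)c3cccc(Cl)c3)n2C)cc1` share one core; compound 3 `Cn1c(-c2ccc(Cl)cc2)cnc1NC(=O)c1ncc[nH]1` and the still unmeasured compound 4 `Cn1c(-c2ccc(C#N)cc2)cnc1NC(=O)c1ncc[nH]1` share another. The difference between the two cores is not broken down here. In a toxicity assay on THP-1 cells (Homo sapiens) for inhibition (on this read-out lower numbers stand for higher toxicity in this test and higher numbers for lower toxicity in this test), compound 1 gives only a limit, > 100000 nM. Compound 2 likewise gives only a limit in this assay, > 28000 nM. Among the compounds with values here, compound 3 gives the only number in this assay, 52000 nM. The change cyano in place of chloro on an aromatic carbon gives the step that the two limits leave unreadable from compound 2 to compound 1, unreadable because the limit of > 100000 nM in this assay, at which 1 of the 3 values shown sits, and the limit of > 28000 nM in this assay, at which 1 of the 3 values shown sits, both sit at limits. The change cyano in place of chloro on an aromatic carbon is the same kind of change, but para rather than meta to a large group. Compound 4 is expected at 65000 nM, between 25000 nM and 150000 nM. The step of a 1.3-fold higher number from compound 3 to compound 4 (0.10 log units; within the scatter) is expected to be small, resting on compound 3 with 52000 nM and on the unreadable measured step.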

Compound 4, half-maximal cytotoxic concentration: > 100000 nM
Compound 4: only a limit was reported; the forecaster's own chance of this, stated with the estimate: 40%; middle value at least 1.5-fold (0.18 log units) away from the limit.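

In this assay, cyano in place of chloro on an aromatic carbon, para to a large group, gives an at least 1.9-fold higher number from compound 3 to compound 4 (0.28 log units; that floor lies within the scatter) on the core of compound 3, and only this floor can be read. On the core of compound 1 the same kind of change gives a step that cannot be read, since the value of compound 2 is a limit, as is that of compound 1: the limit of > 28000 nM in this assay, at which 1 of the 4 values shown sits. Nothing therefore shows that the step carries from one core to the other, nor that it fails to carry.

The compounds shown leave open what an amine or a carboxylic acid in place of chloro would give on either core. They also leave open whether any such replacement on the core of compound 1 would give a number rather than a limit.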